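A few compounds are considered here, and "the series" means these few. Any claim that something is new, unique, unknown or untested is made for them only; others in the source may bear on it.

Compound 1 (`CCCCNC(=O)Nc1cccc2c1CN(C)CC2c1ccccc1`), compound 2 (`CCCCNC(=O)Nc1cccc2c1CN(C)CC2c1ccc(Cl)cc1`) and compound 3 (`CCCCNC(=O)Nc1cccc2c1CN(C)CC2c1ccc(C)cc1`) share one core. In a functional assay on the whole organism for inhibition, with Mus musculus as the target (on this read-out higher numbers stand for an effect only at larger amounts of compound and lower numbers for an effect already at smaller amounts), compound 1 gives 23 mg/kg, compound 2 gives 15 mg/kg and compound 3 gives about 15 mg/kg. Compound 2 thus stands level with compound 3, and compound 1 lies within the scatter of both. Compound 4 (`CCNCC(=O)Nc1cccc2c1CN(C)CC2c1ccc(Cl)cc1`) differs from compound 2 at the carbonyl carbon: (ethylamino)methyl in place of butylamino on a carbonyl carbon. There, (ethylamino)methyl takes the place of butylamino. The measured steps, a 1.5-fold lower number from compound 1 to compound 2 (0.19 log units; within the scatter), a 1.5-fold lower number from compound 1 to compound 3 (0.19 log units; within the scatter) and no change at the digits printed from compound 2 to compound 3 (within the scatter), all lie within the scatter, but each concerns an aromatic carbon, so none indicates a direction for this change. The estimated change is no change at the digits printed from compound 2 to compound 4 (within the scatter), so no step beyond the scatter is expected, though with little certainty. For compound 4 the expected value in this assay is 15 mg/kg, with an estimated range of 5 mg/kg to 45 mg/kg.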

Compound 4, dose for half-maximal effect: 6.4 mg/kg
Beside the measured number, compound 4's estimate is 2.3-fold (0.37 log units) above it; measured number inside the range.
By their numbers in this assay, from the lowest: compound 4; then compounds 2, 3 and 1 (each within the scatter of the next).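

In this assay, among these compounds, the carbonyl carbon is the first place where a change moves the number beyond the scatter: (ethylamino)methyl in place of butylamino gives a 2.3-fold lower number from compound 2 to compound 4 (0.37 log units; beyond the scatter). This one step changes both the chain and the atom bound to the carbonyl carbon, from nitrogen to carbon, and it cannot separate the two. Nothing measured here explains the step. Still open, on these data alone, is how a (methylamino)methyl, a (dimethylamino)methyl or a longer (butylamino)methyl chain would compare. A carboxylic acid at this place also remains untested in the compounds shown.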